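Hydroxyphenyl positional isomers on a shared pyridine core

The source may report more compounds than this note shows. Statements on the series, on what has been measured and on what is new or still open speak of the compounds shown alone.

Of the compounds shown here, three have been measured in an assay on isolated protein for inhibition of DNA topoisomerase 1 (Homo sapiens), with a stated time of 30 min, tested at 100 uM; on this read-out higher numbers stand for more inhibition at the one concentration tested (going by the name of the read-out) and lower numbers for less inhibition. Compound 1 `Oc1cccc(-c2cc(-c3ccccc3O)nc(-c3ccccc3O)c2)c1` gives 4.9%; compound 2 `Oc1cccc(-c2cc(-c3cccc(O)c3)nc(-c3ccccc3O)c2)c1` gives 1.9%; compound 3 `Oc1ccc(-c2cc(-c3cccc(O)c3)cc(-c3ccccc3O)n2)cc1` gives 8.4%. On these numbers compound 1 stands second highest of three: its nearest neighbour is compound 2, a step of a number 3 percentage points lower from compound 1 to compound 2 (within the scatter), and its furthest is compound 3, a step of a number 3.5 percentage points higher from compound 1 to compound 3 (within the scatter). All three values sit inside the scatter of one another, so no order among them can be read.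

Compound 4 `Oc1ccc(-c2cc(-c3ccccc3O)nc(-c3ccccc3O)c2)cc1` has not yet been measured. It differs from compound 1 by 4-hydroxyphenyl in place of 3-hydroxyphenyl on an aromatic carbon; the 3-hydroxyphenyl leaves and a 4-hydroxyphenyl enters, on an aromatic carbon of a six-membered aromatic ring with 1 nitrogen, opposite the ring nitrogen.

The same exchange of hydroxyphenyl groups is seen once in the measured set, as the step of a number 6.5 percentage points higher from compound 2 to compound 3 (within the scatter), which stays within the scatter; the other two steps, from compound 1 to compound 2 and from compound 1 to compound 3, are likewise within the scatter. No shift in this assay beyond the scatter is therefore expected from compound 1 to compound 4. The estimated step is a number 2.1 percentage points higher from compound 1 to compound 4 (within the scatter). Compound 4 is expected to give about 7% in this assay, with a likely range from 0% to 16%.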

Compound 4, a percentage reported as inhibition, at one concentration (the size of the read-out at that concentration, not a potency): 3.7%
Beside the measured number, compound 4's estimate is 3.3 percentage points above it; the measured number falls inside the stated range.
By their numbers in this assay, from the lowest: compounds 2, 4, 1 and 3 (each within the scatter of the next).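

In this assay, putting 4-hydroxyphenyl in place of 3-hydroxyphenyl opposite the ring nitrogen, with the two 2-hydroxyphenyl groups kept, gives a number 1.2 percentage points lower from compound 1 to compound 4 (within the scatter). The exchange can now be read on two cores, and neither its size nor its direction can be told apart between them: the same change on two cores in this assay, a number 6.5 percentage points higher (within the scatter) from compound 2 to compound 3 and a number 1.2 percentage points lower (within the scatter) from compound 1 to compound 4, 7.7 percentage points apart, within the scatter of two such steps. On these two cores, the position opposite the ring nitrogen therefore shows no preference between the 3-hydroxyphenyl and 4-hydroxyphenyl groups.

From the compounds shown here alone, both groups compared here are hydroxyphenyl isomers, so it remains open whether a different group at this position, such as an aminophenyl or a carboxyphenyl, would shift the read-out beyond the scatter. Also open, going by these compounds, is how the compounds would compare at concentrations other than the one tested.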